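Working notes: from compound 3 to compound 4

The source may hold more compounds than are shown below. What is called first, only, known or untested is meant among the compounds shown, and "the series" means these compounds.

In a functional assay on MGC-803 cells (Homo sapiens) for cytotoxicity, read by MTT assay, with a stated time of 72 h (on this read-out lower numbers stand for stronger inhibition and higher numbers for weaker inhibition), the series so far reads as follows
- compound 1 `CN(C)c1ccc(C=C2C(=O)N(c3ccc(Cl)cc3)N(c3ccc(Cl)cc3)C2=O)cc1` gives 80200 nM
- compound 2 `O=C1C(=Cc2ccc(Cl)cc2)C(=O)N(c2ccc(Cl)cc2)N1c1ccc(Cl)cc1` gives 32600 nM
- compound 3 `O=C1C(=Cc2ccc(Br)cc2)C(=O)N(c2ccc(Cl)cc2)N1c1ccc(Cl)cc1` gives 16900 nM

Compound 3 shares the low end of these numbers with compound 2. The step of a 1.9-fold lower number from compound 2 to compound 3 (0.29 log units; within the scatter) stays within the scatter, while the step of a 4.7-fold lower number from compound 1 to compound 3 (0.68 log units; beyond the scatter) is the largest measured.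

Compound 4 `COc1cccc(C=C2C(=O)N(c3ccc(Cl)cc3)N(c3ccc(Cl)cc3)C2=O)c1O` is the next case, with this change 2-hydroxy-3-methoxyphenyl in place of 4-bromophenyl on a double-bonded chain carbon bound to a double-bonded ring carbon placing 2-hydroxy-3-methoxyphenyl in place of 4-bromophenyl on a double-bonded chain carbon bound to a double-bonded ring carbon. Among the measured compounds shown here, no measured step covers such a group. The nearest guides are the modest steps of a 2.5-fold lower number from compound 1 to compound 2 (0.39 log units; beyond the scatter) and a 4.7-fold lower number from compound 1 to compound 3 (0.68 log units; beyond the scatter) in which a halogen replaces dimethylamino, and compound 4 has no halogen on that aromatic ring. A small move toward a higher number is therefore expected, close to the scatter. The expected step is a 1.8-fold higher number from compound 3 to compound 4 (0.25 log units; within the scatter) and no larger than modest. For compound 4 the estimated value is 30000 nM with an expected range from 9000 nM to 80000 nM.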

Compound 4, half-maximal inhibitory concentration: 24300 nM
Beside the measured number, compound 4's estimate is 1.2-fold (0.09 log units) above it, within the range that was stated.
By their numbers in this assay, from the lowest: compounds 3, 4 and 2 (each within the scatter of the next); then compound 1.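

In this assay, 2-hydroxy-3-methoxyphenyl on a double-bonded chain carbon bound to a double-bonded ring carbon gives a 1.4-fold higher number from compound 3 to compound 4 (0.16 log units; within the scatter) and a 1.3-fold lower number from compound 2 to compound 4 (0.13 log units; within the scatter), so among these compounds a ring without halogen stays level with both halogenated rings. Compared with 4-(dimethylamino)phenyl, the same change gives a 3.3-fold lower number from compound 1 to compound 4 (0.52 log units; beyond the scatter), so a non-halogen ring can also sit clear of compound 1. On these data alone, whether a carboxylic acid or a longer chain in place of methoxy would shift the number stays open. No supporting evidence bears on why these steps arise.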